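A few compounds are considered here, and "the series" means these few. Any claim that something is new, unique, unknown or untested is made for them only; others in the source may bear on it.

Compound 1 `Cc1[nH]c2ccccc2c(=O)c1C1CCCCC1`: 2.45
Compound 2 `Cc1[nH]c2ccccc2c(=O)c1Br`: 1.67
Compound 3 `Cc1[nH]c2ccccc2c(=O)c1/C=C/C(=O)OC(C)(C)C`: 2.34

These numbers come from a physicochemical assay for lipophilicity, at pH 7.4; a higher number here means a more lipophilic compound, a lower number a more polar compound. Compound 2 holds the lowest of the three, and compound 3 is the closest to it. Compound 4 `Cc1[nH]c2ccc(F)cc2c(=O)c1Br` is compound 2 with fluoro in place of hydrogen on an aromatic carbon. Within the data shown here, no measured step makes this exchange. Among the measured compounds shown here, the only step available, a number 0.78 log units lower from compound 1 to compound 2 (beyond the scatter), is bromo in place of cyclohexyl, a far bigger exchange at another place, so it offers only a loose ceiling. A small upward step is expected, a number 0.18 log units higher from compound 2 to compound 4 (within the scatter), possibly no more than the scatter. Compound 4 is estimated at 1.85, with a range of 1.55 to 2.2.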

Compound 4, distribution coefficient: 1.61
Compound 4: the middle estimate sits 0.24 log units above what was measured; the measured number falls inside the stated range.
By their numbers in this assay, from the lowest: compounds 4 and 2 (each within the scatter of the next); then compounds 3 and 1 (each within the scatter of the next).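

In this assay there is a number 0.06 log units lower from compound 2 to compound 4 (within the scatter) when fluoro replaces hydrogen on this aromatic carbon, meta to a fused ring and para to a fused ring. Among these compounds, this is the first measured exchange at this position, and with the bromo kept, the two compounds cannot be told apart in this read-out. Nothing available explains this result.

As far as these compounds go, whether an amine or a methoxy group at this same place would shift the number beyond the scatter stays open. So does whether fluoro would give the same result with cyclohexyl in place of the bromo.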